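A few compounds are considered here, and "the series" means these few. Any claim that something is new, unique, unknown or untested is made for them only; others in the source may bear on it.

Measured compounds:
- compound 1, `O=C(O)c1cc(-c2cccc(COc3ccc4c(c3)CN(Cc3ccc(C(F)(F)F)cc3)C4=O)c2)ccc1Cl`, 86.7%
- compound 2, `O=C(O)c1cc(-c2cccc(COc3ccc4c(c3)CN(C3CCCCC3)C4=O)c2)ccc1Cl`, 63.3%
- compound 3, `O=C(O)c1cc(-c2cccc(COc3ccc4c(c3)CN(CC3CC3)C4=O)c2)ccc1Cl`, 85.7%

In an assay on HEK293 cells for positive allosteric modulation of metabotropic glutamate receptor 2 (Rattus norvegicus), read by thallium flux (a lower number here means a smaller maximal response, a higher number a larger maximal response), compound 2 gives the lowest of the three numbers: the step of a number 23.4 percentage points lower from compound 1 to compound 2 (beyond the scatter) and the step of a number 22.4 percentage points higher from compound 2 to compound 3 (beyond the scatter) both lie beyond the scatter, whereas compound 1 and compound 3 stand within the scatter of each other, as a number 1 percentage points lower from compound 1 to compound 3 (within the scatter) shows.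

Compound 4, `O=C(O)c1cc(-c2cccc(COc3ccc4c(c3)CN(C3CC3)C4=O)c2)ccc1Cl`, is not yet measured. It differs from compound 2 in one place:
cyclopropyl in place of cyclohexyl on an amide-type nitrogen in a ring

The step that bears most directly on this change is a number 22.4 percentage points higher from compound 2 to compound 3 (beyond the scatter), where another group with a three-membered ring replaced the same cyclohexyl on the same nitrogen and the maximal response rose modestly. The step of a number 23.4 percentage points lower from compound 1 to compound 2 (beyond the scatter) points the same way: the cyclohexyl compound sits at the bottom of the series. An increase beyond the scatter is therefore expected for a number 14.7 percentage points higher from compound 2 to compound 4 (beyond the scatter), though the cyclopropyl here is joined to the nitrogen without the intervening chain carbon of compound 3, so the size is less certain. Compound 4 is estimated at 78%, within 62% to 94%.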

Compound 4, largest response reached (Emax), in percent of the reference or control that the assay uses: 64.9%
Beside the measured number, compound 4's estimate is 13.1 percentage points above it, within the range that was stated.
By their numbers in this assay, from the lowest: compounds 2 and 4 (each within the scatter of the next); then compounds 3 and 1 (each within the scatter of the next).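

In this assay, cyclopropyl on the amide-type nitrogen in a ring gives no gain over cyclohexyl, with a number 1.6 percentage points higher from compound 2 to compound 4 (within the scatter), so the three-membered ring alone does not carry the higher number of compound 3. The chain carbon matters in this series: removing it gives a number 20.8 percentage points lower from compound 3 to compound 4 (beyond the scatter), and a number 21.8 percentage points lower from compound 1 to compound 4 (beyond the scatter) places compound 4 in the same way below the benzyl compound, so that among these four compounds, the two with a chain carbon on the nitrogen stand above the two with a ring directly on it, with no exception. No supporting evidence is available to explain this difference.

Open, from the compounds shown here alone, is whether a plain benzyl or a longer chain ending in cyclopropyl keeps the larger maximal response. Also open, going by these compounds, is whether an open-chain isopropyl on the nitrogen falls with compound 2 and compound 4.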